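Replacing the aromatic ring of compound 3

The compounds below may be only part of what the source reports. "The series", "measured", "known", "first", "only" and "open" are said of these compounds alone.

Measured in an ADME assay on microsomes from liver (Rattus norvegicus) for metabolic stability; a higher number here means that the compound lasts longer, a lower number that the compound disappears faster:
- compound 1 `CC(C)C(Cc1nnc[nH]1)c1ccc(-c2ccc3cccc(F)c3c2)[nH]c1=O`: 0.1 h
- compound 2 `CC(C)C(c1ccc(-c2ccc3cccc(F)c3c2)[nH]c1=O)N1CCN/C1=N\C#N`: 0.327 h
- compound 3 `CC(C)C(c1noc(=O)[nH]1)c1ccc(-c2ccc3cccc(F)c3c2)[nH]c1=O`: > 3 h (a limit)

Compound 3 gives > 3 h in this assay, which is a limit of the assay and not a number. Its half-life is therefore known from one side only.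

Compound 4 `CC(C)C(/C=C1/CCNC1=O)c1ccc(-c2ccc3cccc(F)c3c2)[nH]c1=O` keeps the shared core and changes only the group on the saturated chain carbon bound to an aromatic carbon and a saturated chain carbon: a group of 7 heavy atoms (5 carbon, 1 nitrogen, 1 oxygen; one five-membered non-aromatic ring with 1 hetero atom) in place of a group of 6 heavy atoms (2 carbon, 2 nitrogen, 2 oxygen; one five-membered aromatic ring with 3 hetero atoms), on a saturated chain carbon bound to an aromatic carbon and a saturated chain carbon. The five-membered aromatic ring with 3 hetero atoms gives way to a five-membered non-aromatic ring with 1 hetero atom.

All three measured steps were changes at this same place. The series shows a 3.3-fold higher number from compound 1 to compound 2 (0.51 log units; beyond the scatter), then an at least 30-fold higher number from compound 1 to compound 3 (1.47 log units; beyond the scatter). The nearest guide is an at least 9.1-fold higher number from compound 2 to compound 3 (0.96 log units; beyond the scatter), since the group left behind in that step is also a five-membered non-aromatic ring. Read in reverse, these steps suggest that giving up the group of compound 3 costs half-life, though no measured compound carries the entering group itself.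

A fall beyond the scatter is expected, and the estimated change is an at least 6.0-fold lower number from compound 3 to compound 4 (0.77 log units; beyond the scatter). Compound 4 is estimated at 0.5 h, with an expected range from 0.12 h to 2.5 h.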

Compound 4, half-life: 0.06 h
Compound 4: the middle estimate sits 8.3-fold (0.92 log units) above what was measured, and the stated range ends above it.
By their numbers in this assay, from the lowest: compounds 4 and 1 (each within the scatter of the next); then compound 2. At a limit, above all of these: compound 3.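

In this assay, the five-membered non-aromatic ring with 1 hetero atom does not keep what the group of compound 3 gives at this place: an at least 50-fold lower number from compound 3 to compound 4 (1.69 log units; beyond the scatter). Compound 3 gives > 3 h, which is a limit of the assay and not a number, so the size of this step is known from one side only: the limit of > 3 h in this assay, at which 1 of the 4 values shown sits. Nor does a five-membered non-aromatic ring at this place settle the outcome, for a 5.5-fold lower number from compound 2 to compound 4 (0.74 log units; beyond the scatter), while a 1.7-fold lower number from compound 1 to compound 4 (0.22 log units; within the scatter), which leaves compound 4 level with compound 1 and compound 3 alone standing apart from compounds 1, 2 and 4.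

The compounds shown leave open how long compound 3 actually lasts, and which part of its group goes with that result, since each step here exchanges the whole group on the saturated chain carbon. A carboxylic acid or an amine at the same place would show whether a half-life like that of compound 3 is tied to its five-membered aromatic ring with 3 hetero atoms or can be reached without any such ring.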